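A few compounds are considered here, and "the series" means these few. Any claim that something is new, unique, unknown or untested is made for them only; others in the source may bear on it.

Of the compounds shown here, three built on one shared core have been measured in an assay on isolated protein for inhibition of Rho-associated protein kinase 2 (Homo sapiens), tested at 1 uM; on this read-out higher numbers stand for more inhibition at the one concentration tested (going by the name of the read-out) and lower numbers for less inhibition. Compound 1 `CCNCc1ccc(N/C(=C2\C(=O)Nc3cc(C(=O)N(C)CC)ccc32)c2ccccc2)cc1` gives 80%, compound 2 `CN(C)C(=O)c1ccc2c(c1)/C(=C(/Nc1ccc(CN3CCCCC3)cc1)c1ccccc1)C(=O)N2` gives 79%, and compound 3 `CCNC(=O)c1ccc2c(c1)NC(=O)/C2=C(\Nc1ccc(CN(C)C)cc1)c1ccccc1` gives 95%. Compound 2 stands at the lowest of the three numbers, though its gap to compound 1 is within the usual scatter of repeated measurements, while its gap to compound 3 is beyond it. All three carry an amide on the same aromatic carbon of the core; they differ in the groups on that amide and on the distal benzylic amine.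

Compound 4 `O=C1Nc2ccccc2/C1=C(/Nc1ccc(CN2CCCCC2)cc1)c1ccccc1` removes that amide altogether. Set against compound 2, the change is hydrogen in place of dimethylcarbamoyl on an aromatic carbon. For the measured compounds named here, no measured pair in this set shows what removing the group does, so its effect is unknown and the expectation rests on the three amides all sitting at high inhibition. Because compound 2 reaches 79% with the group in place, a drop beyond the scatter is expected on going a number 24 percentage points lower from compound 2 to compound 4 (beyond the scatter). Compound 4 is estimated at 55%, between 20% and 85%.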

Compound 4, a percentage reported as inhibition, at one concentration (the size of the read-out at that concentration, not a potency): 54%
Compound 4: middle estimate off by 1 percentage points, on the high side; low and high end bracket the measured number.
By their numbers in this assay, from the lowest: compound 4; then compounds 2 and 1 (each within the scatter of the next); then compound 3.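

Taking away the dimethylcarbamoyl group and leaving hydrogen on that aromatic carbon gives a number 25 percentage points lower from compound 2 to compound 4 (beyond the scatter) in this assay. For the compounds shown here, nothing else differs between the two, so this pair is the first direct reading of this position, and it shows that the amide counts for part of the inhibition at the one concentration tested. Even so, compound 4 still reaches 54% with no amide at all, and no other measurement here bears on why the number falls.

This one pair sets hydrogen against a single amide, with a single amine at the far end of the molecule. On these data alone, it remains open whether a nitrile or a carboxylic acid on that aromatic carbon would serve as well as the dimethylcarbamoyl group, and whether removing the amide costs as much when other distal benzylic amines are present.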